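Replacing Chloromethyl with Hydrogen in Two Sulfonamide Ureas

A few compounds are considered here, and "the series" means these few. Any claim that something is new, unique, unknown or untested is made for them only; others in the source may bear on it.

Of the compounds shown here, three have been tested in a functional assay on HT-29 cells (Homo sapiens) for cytotoxicity, read by sulforhodamine B assay, with a stated time of 48 h; on this read-out lower numbers stand for stronger inhibition and higher numbers for weaker inhibition. Compound 1 `Cc1ccccc1NS(=O)(=O)c1cccc(NC(=O)NCCCCl)c1` gives 42000 nM, compound 3 `CCNC(=O)Nc1cccc(S(=O)(=O)Nc2ccccc2C)c1` gives 102000 nM, and compound 2 `Cc1ccccc1NS(=O)(=O)c1ccc(NC(=O)NCCCCl)cc1` gives 64000 nM. Compound 3 differs from compound 1 by hydrogen in place of chloromethyl on a saturated chain carbon, two bonds along the chain from an amide-type nitrogen, and that change produced a 2.4-fold higher number from compound 1 to compound 3 (0.39 log units; beyond the scatter). Compound 4 `CCNC(=O)Nc1ccc(S(=O)(=O)Nc2ccccc2C)cc1` has not yet been measured; it differs from compound 2 by hydrogen in place of chloromethyl on a saturated chain carbon, two bonds along the chain from an amide-type nitrogen, the same change at the same place. The difference between the cores of compound 1 and compound 2 is not broken down here, and their values lie within the scatter of one another. Resting on the measured step of a 2.4-fold higher number from compound 1 to compound 3 (0.39 log units; beyond the scatter), a step of similar size is expected for compound 4: a 2.3-fold higher number from compound 2 to compound 4 (0.37 log units; beyond the scatter). Compound 4 is therefore estimated to give about 150000 nM in this assay, likely between 70000 nM and 350000 nM.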

Compound 4, half-maximal inhibitory concentration: > 200000 nM
Compound 4: a limit, no number; the forecaster's own chance of this, stated with the estimate: 25%; middle value at least 1.3-fold (0.12 log units) from the limit.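

In this assay compound 4 gives > 200000 nM, which is a limit of the assay and not a number. Even so, putting hydrogen in place of chloromethyl on this second core gives an at least 3.1-fold higher number from compound 2 to compound 4 (0.49 log units; beyond the scatter), so the change points the same way on both cores, towards weaker inhibition. This shows that the direction of the change carries over between these two cores, but not that its size does: the same change on two cores in this assay, a 2.4-fold higher number (0.39 log units; beyond the scatter) from compound 1 to compound 3 and an at least 3.1-fold higher number (0.49 log units; beyond the scatter) from compound 2 to compound 4; the limit leaves it open whether they differ

The compounds shown leave open what a plain propyl chain, a 2-chloroethyl chain or an amine at the end of the chain would give on either core. They therefore cannot separate the part played by the chlorine from the part played by chain length.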